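A few compounds are considered here, and "the series" means these few. Any claim that something is new, unique, unknown or untested is made for them only; others in the source may bear on it.

Measured compounds:
compound 1, `CCNCC(=O)Nc1cc(OC)ccc1C(=O)c1ccc(OC)c2c1OC(C)(C)C=C2`, 5200 nM
compound 2, `COc1ccc(C(=O)c2ccc(OC)c3c2OC(C)(C)C=C3)c(NC(=O)CN(C)C)c1`, 2680 nM
compound 3, `CCNCC(=O)Nc1cc(OC)ccc1C(=O)c1cc(OC)c(OC)c(OC)c1`, 1050 nM

All three were tested in a functional assay on MCF7 cells (Homo sapiens) for antiproliferative activity, read by MTT assay, with a stated time of 48 h; a lower number here means a stronger inhibitor, a higher number a weaker inhibitor. Compound 1 and compound 2 share one core and differ only by dimethylamino in place of ethylamino on a saturated chain carbon bound to a carbonyl carbon. That change made a 1.9-fold lower number from compound 1 to compound 2 (0.29 log units; within the scatter). Compound 3 carries a different core; the difference between the two cores is not broken down here. Among the three measured compounds, compound 3 has the lowest number, with its step to compound 2 and its step to compound 1 both beyond the scatter.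

Compound 4, `COc1ccc(C(=O)c2cc(OC)c(OC)c(OC)c2)c(NC(=O)CN(C)C)c1`, is not yet measured. It stands to compound 3 as compound 2 stands to compound 1: the change is dimethylamino in place of ethylamino on a saturated chain carbon bound to a carbonyl carbon, the same change, at the same place. Given that the step of a 1.9-fold lower number from compound 1 to compound 2 (0.29 log units; within the scatter) stayed within the scatter, the corresponding step on the core of compound 3 is expected to be small as well. Compound 4 is therefore expected to give about 700 nM in this assay, between 350 nM and 1500 nM, which would mean an expected step of a 1.5-fold lower number from compound 3 to compound 4 (0.18 log units; within the scatter).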

Compound 4, half-maximal inhibitory concentration: 790 nM
For compound 4 the middle estimate is 1.1-fold (0.05 log units) below the measured one, within the range that was stated.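

In this assay, dimethylamino in place of ethylamino on the second core gave a 1.3-fold lower number from compound 3 to compound 4 (0.12 log units; within the scatter), so this step, like the first, stays within the scatter. Set side by side, the two steps cannot be told apart: the same change on two cores in this assay, a 1.9-fold lower number (0.29 log units; within the scatter) from compound 1 to compound 2 and a 1.3-fold lower number (0.12 log units; within the scatter) from compound 3 to compound 4, 1.5-fold (0.16 log units) apart, within the scatter of two such steps. Among the compounds shown here, this shows that, on these two cores, the change carried across without a step that stands out from the scatter, but it rests on only two pairs in one cell assay and shows neither that the change is without any effect nor that it would behave the same way on a further core.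

The compounds shown leave open what a primary amine or a cyclic amine such as morpholine would give in place of dimethylamino on a saturated chain carbon bound to a carbonyl carbon. They also leave open whether a longer chain carrying the same dimethylamino group would keep the numbers seen on either core.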